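Replacing the 2,4-Dichlorophenyl Amide with Methoxycarbonyl

The source may hold more compounds than are shown below. What is called first, only, known or untested is meant among the compounds shown, and "the series" means these compounds.

Compound 1 `COc1cc(/C=C/C(=O)c2cccc(NC(=O)c3cccs3)c2)ccc1O` gives 80% in a functional assay on HUVEC cells (Homo sapiens) for inhibition, tested at 5 ug/mL; on this read-out lower numbers stand for a weaker effect and higher numbers for a stronger effect at the one concentration tested.
Compound 2 `COc1cc(/C=C/C(=O)c2cccc(NC(=O)c3ccc(Cl)cc3)c2)ccc1O` gives 42%.
Compound 3 `COc1cc(/C=C/C(=O)c2cccc(NC(=O)c3ccc(Cl)cc3Cl)c2)ccc1O` gives 51%.

Compound 3 stands second highest of the three numbers; the gap to compound 2, a number 9 percentage points higher from compound 2 to compound 3 (within the scatter), lies within the scatter, while compound 1 lies beyond it, a number 29 percentage points lower from compound 1 to compound 3 (beyond the scatter). Compound 4 `COC(=O)C(=O)Nc1cccc(C(=O)/C=C/c2ccc(O)c(OC)c2)c1` differs from compound 3 in one place: methoxycarbonyl in place of 2,4-dichlorophenyl on a carbonyl carbon. For the measured compounds named here, no measured step replaces a ring by a chain here, so only indirect guidance exists: a number 38 percentage points lower from compound 1 to compound 2 (beyond the scatter) and a number 29 percentage points lower from compound 1 to compound 3 (beyond the scatter) show that the group on this carbonyl carbon can move this assay a great deal, whereas a number 9 percentage points higher from compound 2 to compound 3 (within the scatter) shows that a small change there does little. Compound 4 is therefore estimated at 45%, within 20% to 75%. The expected step of a number 6 percentage points lower from compound 3 to compound 4 (within the scatter) lies within the scatter, with wide uncertainty.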

Compound 4, a percentage reported as inhibition, at one concentration (the size of the read-out at that concentration, not a potency): 20%
Estimate against measurement, compound 4: 25 percentage points above; low and high end bracket the measured number.
By their numbers in this assay, from the lowest: compound 4; then compounds 2 and 3 (each within the scatter of the next); then compound 1.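

For the compounds shown here, compound 4 is the weakest of the four in this assay, and it is the first compound here without a ring on this carbonyl carbon. Replacing each ring with methoxycarbonyl lowers the number, whether the ring is 2,4-dichlorophenyl (a number 31 percentage points lower from compound 3 to compound 4 (beyond the scatter)), 4-chlorophenyl (a number 22 percentage points lower from compound 2 to compound 4 (beyond the scatter)) or thiophen-2-yl (a number 60 percentage points lower from compound 1 to compound 4 (beyond the scatter)). No available evidence explains this loss.

The compounds shown leave open whether losing the ring or gaining methoxycarbonyl drives the drop. A cyclohexyl ring, a carboxylic acid or a longer alkyl chain on this carbon could help separate the two.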